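The compounds below may be only part of what the source reports. "The series", "measured", "known", "first", "only" and "open" are said of these compounds alone.

Three amides built on one shared core have been measured in an assay on isolated protein for inhibition of phosphodiesterase 4A (Sus scrofa); on this read-out higher numbers stand for weaker inhibition and lower numbers for stronger inhibition. Compound 1 `COc1ccc(C(=O)Nc2ccccc2Cl)cc1OC1CCCC1` gives 190 nM in this assay, and compound 2 `COc1ccc(C(=O)Nc2c(C)cccc2Cl)cc1OC1CCCC1` gives 100 nM, the step of a 1.9-fold lower number from compound 1 to compound 2 (0.28 log units; within the scatter) lying within the scatter. Compound 3 `COc1ccc(C(=O)Nc2ccccc2O)cc1OC1CCCC1` gives 1300 nM in this assay, the highest of the three numbers; the two steps leading to it read a 6.8-fold higher number from compound 1 to compound 3 (0.84 log units; beyond the scatter) and a 13-fold higher number from compound 2 to compound 3 (1.11 log units; beyond the scatter), both beyond the scatter. Compound 4 `COc1ccc(C(=O)Nc2cnccn2)cc1OC1CCCC1` has not yet been measured. It differs from compound 3 in one place: pyrazin-2-yl in place of 2-hydroxyphenyl on an amide-type nitrogen. Within the data shown here, none of the measured steps exchanges the ring on the amide nitrogen for a ring with hetero atoms, so no step bears on this change directly. On these data alone, what the data do show is that compound 3, the only one carrying a hydroxy on that ring, stands well above compounds 1 and 2, so removing that ring may well move the number back toward theirs, though a pyrazin-2-yl ring is untested here and the uncertainty is wide. Compound 4 is therefore expected to give about 300 nM in this assay, within a range from 60 nM to 2000 nM. That estimate corresponds to a 4.3-fold lower number from compound 3 to compound 4 (0.64 log units; beyond the scatter).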

Compound 4, half-maximal inhibitory concentration: 250 nM
For compound 4 the middle estimate is 1.2-fold (0.08 log units) above the measured one; the measured number falls inside the stated range.
By their numbers in this assay, from the lowest: compounds 2, 1 and 4 (each within the scatter of the next, the first and the last beyond it); then compound 3.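

In this assay, the amide-type nitrogen proves able to carry a ring with hetero atoms and no hydroxy, and the exchange of 2-hydroxyphenyl for pyrazin-2-yl is a modest step beyond the scatter (a 5.2-fold lower number from compound 3 to compound 4 (0.72 log units; beyond the scatter)). Against the two chlorinated compounds the picture divides: the step from 2-chlorophenyl stays within the scatter (a 1.3-fold higher number from compound 1 to compound 4 (0.12 log units; within the scatter)), whereas the step from 2-chloro-6-methylphenyl lies beyond it (a 2.5-fold higher number from compound 2 to compound 4 (0.40 log units; beyond the scatter)). No measurement at hand accounts for these differences.

Still open, on these data alone, is what the ring nitrogens of pyrazin-2-yl contribute on their own, which an unsubstituted phenyl or a pyridin-2-yl ring on the same nitrogen would address. Also open, as far as these compounds go, is how an amine or a methoxy group in place of the hydroxy of compound 3 would read.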